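A few compounds are considered here, and "the series" means these few. Any claim that something is new, unique, unknown or untested is made for them only; others in the source may bear on it.

Series notes. The shared core is that of compound 1, `CCN1CCN(c2cc(C)c3cc(NC(=O)c4ccc(F)cc4)ccc3n2)CC1`, which in a functional assay on SK-BR-3 cells (Homo sapiens) for antiproliferative activity, read by MTT assay, with a stated time of 72 h (a higher number here means a weaker inhibitor, a lower number a stronger inhibitor), gives 19800 nM. Compound 2, `CCN1CCN(c2cc(C)c3cc(NC(=O)c4cccnc4)ccc3n2)CC1`, gives 10600 nM in this assay, and compound 3, `CCN1CCN(c2cc(C)c3cc(NC(=O)c4ccccc4C)ccc3n2)CC1`, gives 29200 nM. Among these three numbers compound 1 stands second highest; the steps of a 1.9-fold lower number from compound 1 to compound 2 (0.27 log units; within the scatter) and a 1.5-fold higher number from compound 1 to compound 3 (0.17 log units; within the scatter) both stay within the scatter, while a 2.8-fold higher number from compound 2 to compound 3 (0.44 log units; beyond the scatter) is the only step beyond it. Compound 4, `CCN1CCN(c2cc(C)c3cc(NC(=O)c4cc5ccccc5[nH]4)ccc3n2)CC1`, is not yet measured in this assay. Its change from compound 1: 1H-indol-2-yl in place of 4-fluorophenyl on a carbonyl carbon. Both measured steps from compound 1 exchange the group on the carbonyl carbon for another single aromatic ring, and neither moved the number beyond the scatter. Within the data shown here, no measured step covers a group with two fused rings or one carrying a hydrogen-bond donor, so the change to 1H-indol-2-yl lies outside the measured exchanges. From compound 1 the expected step is a 1.3-fold lower number from compound 1 to compound 4 (0.12 log units; within the scatter), no larger than the scatter but with a wide band. Compound 4 is estimated at 15000 nM, between 5000 nM and 50000 nM.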

Compound 4, half-maximal inhibitory concentration: 2550 nM
Compound 4: middle estimate off by 5.9-fold (0.77 log units), on the high side, and the stated range ends above it.
By their numbers in this assay, from the lowest: compound 4; then compounds 2, 1 and 3 (each within the scatter of the next, the first and the last beyond it).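

Among the single aromatic rings on this carbonyl carbon, the widest step in this assay is a 2.8-fold higher number from compound 2 to compound 3 (0.44 log units; beyond the scatter) and the exchange for 1H-indol-2-yl reaches further, with a 7.8-fold lower number from compound 1 to compound 4 (0.89 log units; beyond the scatter) as its step from the 4-fluorophenyl compound. The other two steps, a 4.2-fold lower number from compound 2 to compound 4 (0.62 log units; beyond the scatter) and an 11-fold lower number from compound 3 to compound 4 (1.06 log units; beyond the scatter), are also beyond the scatter, which makes compound 4 the strongest inhibitor of the four and shows that this position tolerates more than a single ring. The change brings in a second ring and a hydrogen-bond donor together, and no supporting data bear on what lies behind the lower number. Open is whether the second ring or the donor carries the step, as no compound shown has one without the other. Also open, from the compounds shown here alone, is how an amine or a carboxylic acid on the 1H-indol-2-yl group would read.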